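Swapping the Dichlorophenyl of Compound 1 for Dimethylphenyl

The source may hold more compounds than are shown below. What is called first, only, known or untested is meant among the compounds shown, and "the series" means these compounds.

Measured so far:
compound 1 `COC(=O)C1=C(C)N=C(C)/C(=C(\O)OC)C1c1c(Cl)cccc1Cl`: 1.91 nM
compound 2 `COC(=O)C1=C(C)N=C(C)/C(=C(\O)OC)C1c1cccc(N(C)C)c1`: 891 nM
compound 3 `COC(=O)C1=C(C)N=C(C)/C(=C(\O)OC)C1c1cc([N+](=O)[O-])ccc1Cl`: 30.2 nM

In a functional assay (muscle tissue) with Cavia porcellus as the target (on this read-out lower numbers stand for an effect already at smaller amounts and higher numbers for an effect only at larger amounts of compound), compound 1 gives 1.91 nM, the lowest of the three numbers; compound 3 lies beyond the scatter from it, and compound 2 lies further still. Compound 4 `COC(=O)C1=C(C)N=C(C)/C(=C(\O)OC)C1c1cc(C)ccc1C` has not yet been measured. It differs from compound 1 in one place: 2,5-dimethylphenyl in place of 2,6-dichlorophenyl on a saturated ring carbon. Compound 3, which keeps a chlorine on the ring, already sits well above compound 1, and compound 2, without chlorine, sits highest. From this a step upward beyond the scatter is expected, a 21-fold higher number from compound 1 to compound 4 (1.32 log units; beyond the scatter). For compound 4 the estimate in this assay is therefore 40 nM, with a range from 8 nM to 200 nM.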

Compound 4, half-maximal effective concentration: 100 nM
Estimate against measurement, compound 4: 2.5-fold (0.40 log units) below, and the stated range covers the measured number.
By their numbers in this assay, from the lowest: compound 1; then compound 3; then compound 4; then compound 2.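

In this assay, going by these compounds alone, 2,5-dimethylphenyl in place of 2,6-dichlorophenyl gives a 52-fold higher number from compound 1 to compound 4 (1.72 log units; beyond the scatter), the first comparison here of two compounds that differ in one place. This shows that the number at this saturated ring carbon can change greatly when the aryl group changes. The step is large even though both groups have the same heavy-atom count and neither has hydrogen-bond donors or acceptors.

From the compounds shown here alone, how a fluorine or a methoxy group on the ring would read remains open. Nothing measured here gives a reason for the step.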